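Diaryl methanes in HeLa cytotoxicity: nitro to hydroxy

The compounds below may be only part of what the source reports. "The series", "measured", "known", "first", "only" and "open" are said of these compounds alone.

Measured compounds:
compound 1 `COc1ccc(C(O)c2ccc3c(ccn3C)c2)c(OC)c1OC`: 2500 nM
compound 2 `COc1ccc(Cc2ccc3ccccc3c2)c(OC)c1OC`: 200 nM
compound 3 `COc1ccc(Cc2cc(OC)c(OC)c(OC)c2)cc1[N+](=O)[O-]`: 300 nM

Three compounds have been run in a functional assay on HeLa cells (Homo sapiens) for cytotoxicity, read by XTT assay, with a stated time of 72 h; a lower number here means a stronger inhibitor, a higher number a weaker inhibitor. Compound 1 gives 2500 nM. Compound 2 gives 200 nM. Compound 3 gives 300 nM. On these numbers compound 3 stands second highest of the three: its nearest neighbour is compound 2, whose number is lower by an amount within the scatter, so the two cannot be ordered; compound 1 is furthest, with a higher number that lies beyond the scatter. Among the compounds with values here, no pair of measured compounds differs in one place only, so no single step has been isolated yet.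

Compound 4 `COc1ccc(Cc2cc(OC)c(OC)c(OC)c2)cc1O` is the next compound for this assay. It differs from compound 3 as follows: hydroxy in place of nitro on an aromatic carbon. Neither the hydroxy nor the nitro group at this place has a counterpart among the measured compounds, so the direction of the step rests on no shown comparison. A small step is expected, toward a lower number or none beyond the scatter, giving an estimated 2.0-fold lower number from compound 3 to compound 4 (0.30 log units; within the scatter). Compound 4 is estimated at 150 nM, with a range from 40 nM to 600 nM.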

Compound 4, half-maximal inhibitory concentration: 2.9 nM
Estimate against measurement, compound 4: 52-fold (1.71 log units) above, and the stated range ends above it.
By their numbers in this assay, from the lowest: compound 4; then compounds 2 and 3 (each within the scatter of the next); then compound 1.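

In this assay the step of a 100-fold lower number from compound 3 to compound 4 (2.01 log units; beyond the scatter) is large and lies well beyond the scatter, which makes it the first single-place change isolated in this series and shows that the result at this position depends strongly on the group carried there. The position is an aromatic carbon of a six-membered aromatic ring of carbon only, ortho to a methoxy group and meta to a large group, and the nitro group of compound 3 is not required for activity here, since with hydroxy at this place compound 4 gives 2.9 nM in this assay on the same remaining structure. The change replaces a nitro group of 3 heavy atoms and 0 hydrogen-bond donors with a hydroxy group of 1 heavy atom and 1 hydrogen-bond donor, but nothing available indicates which of these differences accounts for the size of the step.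

On these data alone, the series holds only these two groups at this place, so what an amine, a fluorine atom or a longer alkoxy chain would give there remains open. As far as these compounds go, it is also open whether hydroxy in place of nitro would produce a step of similar size on another core, as this change rests on a single pair.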